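Amine swap on the sulfonyl chain: compound 3 to compound 4

The compounds below may be only part of what the source reports. "The series", "measured", "known", "first", "only" and "open" are said of these compounds alone.

The series shares one core carrying a sulfonyl-linked saturated chain ending in an amine. In a physicochemical assay for lipophilicity (a lower number here means a more polar compound, a higher number a more lipophilic compound), compound 3 `CCN(CC)CCCS(=O)(=O)c1ccc2nc(NC(=O)NC(=O)c3cc(-n4cccn4)ccc3Cl)sc2c1` gives 2.1. Compound 1 `COc1cc(Cl)c(C(=O)NC(=O)Nc2nc3ccc(S(=O)(=O)CCCN4CCN(C)CC4)cc3s2)cc1-n1cccn1` gives 2.2 and compound 2 `CCOc1ccc(Cl)c(C(=O)NC(=O)Nc2nc3ccc(S(=O)(=O)CCCN4CCN(C)CC4)cc3s2)c1` gives 2.4 in this assay; both sit within the usual scatter of compound 3, so no real separation is shown between the three, and no pair of them differs in one place only.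

Compound 4 `CN1CCN(CCCS(=O)(=O)c2ccc3nc(NC(=O)NC(=O)c4cc(-n5cccn5)ccc4Cl)sc3c2)CC1` is the direct partner of compound 3 in this assay. The change is 4-methylpiperazin-1-yl in place of diethylamino on a saturated chain carbon, three bonds along the chain from a sulfonyl sulfur. Compound 1 and compound 2 already carry the 4-methylpiperazin-1-yl group, with other groups on the acyl ring, and their numbers in this assay sit close to compound 3.

For compound 4 the step from the value of compound 3 is expected to be a number 0.10 log units lower from compound 3 to compound 4 (within the scatter), small and downward, not beyond the scatter. Compound 4 is therefore estimated at 2 in this assay, within 1.6 to 2.4.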

Compound 4, distribution coefficient: 2
Compound 4: the middle estimate sits on the measured number at the digits printed; the measured number falls inside the stated range.
By their numbers in this assay, from the lowest: compounds 4, 3, 1 and 2 (each within the scatter of the next, the first and the last beyond it).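

In this assay, within the data shown here, the swap gives the first one-place reading at this chain position: 4-methylpiperazin-1-yl in place of diethylamino on a saturated chain carbon, three bonds along the chain from a sulfonyl sulfur, is a number 0.10 log units lower from compound 3 to compound 4 (within the scatter) and shows no real separation. Among these compounds, with 4-methylpiperazin-1-yl held constant, 1H-pyrazol-1-yl in place of ethoxy on an aromatic carbon is a number 0.40 log units lower from compound 2 to compound 4 (beyond the scatter) and the only step here beyond the scatter, while hydrogen in place of methoxy on an aromatic carbon is a number 0.20 log units lower from compound 1 to compound 4 (within the scatter) and shows no real separation. No supporting data bear on these steps.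

Going by these compounds, whether other amines on this chain, such as morpholine or a primary amine, or a shorter or longer chain would also stay this close remains open. The amine swap is read on one background only, so its size with other groups elsewhere on the molecule is also unknown.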